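A chlorine moved around the benzyl ring

The source may report more compounds than this note shows. Statements on the series, on what has been measured and on what is new or still open speak of the compounds shown alone.

Compound 2 `CCC1(Cc2ccccc2)OS(=O)(=O)C=C1OCc1ccccc1Cl` carries a 2-chlorophenyl group, and in an ADME assay on HEL cells (Homo sapiens) for cytotoxicity, with a stated time of 3 days (a higher number here means that more compound is tolerated, a lower number that less compound is tolerated), compound 2 gives only a limit of the assay, >= 20000 nM. Compound 1 `CCC1(Cc2ccccc2)OS(=O)(=O)C=C1OCc1ccc(OC)cc1` in this assay also gives only a limit, >= 200000 nM. The step that the two limits leave unreadable from compound 1 to compound 2 therefore cannot be read. Compound 3 `CCC1(Cc2ccccc2)OS(=O)(=O)C=C1OCc1ccc(Cl)cc1` differs from compound 2 by 4-chlorophenyl in place of 2-chlorophenyl on a saturated chain carbon bound to an oxygen on an unsaturated carbon. Going by the values given here, no measured step mirrors this change, and both values so far sit at limits, so no shift beyond the scatter is expected. The step that the limit leaves unreadable from compound 2 to compound 3 is expected to be small. Compound 3 is expected to give about 40000 nM, within 10000 nM to 200000 nM, probably again as a limit.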

Compound 3, minimum cytotoxic concentration: >= 50000 nM
Compound 3 gave a limit, no number (the forecaster's own chance of this, stated with the estimate: 80%); middle value at least 1.2-fold (0.09 log units) from the limit.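

Going by these compounds alone, compound 1, compound 2 and compound 3 all stand at limits in this assay, so no step among them can be read. From the compounds shown here alone, what remains open is how much compound each tolerated amount truly reaches, and whether moving the chlorine changes it.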